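Ring-opened dithiocarbamate: compound 4 against compound 2

The compounds below may be only part of what the source reports. "The series", "measured", "known", "first", "only" and "open" are said of these compounds alone.

Compound 2 `Cc1ncc([N+](=O)[O-])n1CC(O)CSC(=S)N1CCCCC1` stands second highest of the three numbers in a toxicity assay on HeLa cells (Homo sapiens) for cytotoxicity, read by MTT assay, with a stated time of 24 h (on this read-out lower numbers stand for stronger inhibition and higher numbers for weaker inhibition), where compound 2 gives 1400000 nM. Its nearest neighbour is compound 3 `Cc1ncc([N+](=O)[O-])n1CC(O)CSC(=S)N1CCC(Cc2ccccc2)CC1`, which gives 1320000 nM, and the furthest is compound 1 `Cc1ncc([N+](=O)[O-])n1CC(O)CSC(=S)N1CCN(c2ncccn2)CC1`, which gives 2040000 nM; both gaps lie within the scatter. Compound 4 `CCN(CC)C(=S)SCC(O)Cn1c([N+](=O)[O-])cnc1C` differs from compound 2 by diethylamino in place of piperidin-1-yl on a thiocarbonyl carbon. Among the measured compounds shown here, the only measured step, a 1.1-fold lower number from compound 2 to compound 3 (0.03 log units; within the scatter), touches the same saturated ring but adds a benzyl rather than opening the ring, so it bears on compound 4 only loosely; it shows no movement beyond the scatter. Compound 4 is therefore expected to sit close to compound 2, with a step of a 1.1-fold higher number from compound 2 to compound 4 (0.03 log units; within the scatter) in this assay. The estimate for compound 4 is 1500000 nM, ranging from 700000 nM to 3200000 nM.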

Compound 4, half-maximal inhibitory concentration: 2460000 nM
Estimate against measurement, compound 4: 1.6-fold (0.21 log units) below; the range from low to high includes it.
By their numbers in this assay, from the lowest: compounds 3, 2, 1 and 4 (each within the scatter of the next).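

In this assay, among the compounds shown here, replacing piperidin-1-yl with diethylamino on a thiocarbonyl carbon gives a 1.8-fold higher number from compound 2 to compound 4 (0.24 log units; within the scatter), the first step here that removes the ring from this place rather than substituting it. Compound 4 thus shows that an open-chain amine at this place, with no ring, still gives a step that stays within the scatter. Nothing given here bears on why the step has this size. On these data alone, it remains open whether dimethylamino, dibutylamino or morpholin-4-yl on the same thiocarbonyl carbon would give a step beyond the scatter.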